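A few compounds are considered here, and "the series" means these few. Any claim that something is new, unique, unknown or untested is made for them only; others in the source may bear on it.

Measured in an ADME assay on the whole organism with Oryza sativa as the target, tested at 0.1 uM; on this read-out lower numbers stand for a stronger effect and higher numbers for a weaker effect at the one concentration tested:
compound 1 `Cc1ccc(NC(=O)N[C@H](C)c2ccccc2)cc1`, 100%
compound 2 `CC(C)c1ccc(NC(=O)N[C@H](C)c2ccccc2)cc1`, 99%
compound 3 `CCCCCCCc1ccc(NC(=O)N[C@H](C)c2ccccc2)cc1`, 100%

Compound 3 stands level with compound 1 at the digits printed, and its step of a number 1 percentage points higher from compound 2 to compound 3 (within the scatter) lies within the scatter, so the three measured values cannot be told apart in this assay.

Compound 4 `C[C@@H](NC(=O)Nc1ccc(I)cc1)c1ccccc1` differs from compound 3 by iodo in place of heptyl on an aromatic carbon. All measured steps touch this same position of the ring and are all within the scatter: a number 1 percentage points lower from compound 1 to compound 2 (within the scatter), no change at the digits printed from compound 1 to compound 3 (within the scatter), a number 1 percentage points higher from compound 2 to compound 3 (within the scatter). Within the data shown here, no measured compound carries a halogen at this position, so that part of the change is untested. Still, with every measured change at this site flat, compound 4 is expected to give 99%, in the range 90% to 103%. The expected step of a number 1 percentage points lower from compound 3 to compound 4 (within the scatter) is within the scatter.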

Compound 4, a percentage reported as activity, at one concentration (the size of the read-out at that concentration, not a potency): 100%
Estimate against measurement, compound 4: 1 percentage points below; measured number inside the range.
By their numbers in this assay, from the lowest: compounds 2, 1, 3 and 4 (each within the scatter of the next).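

In this assay iodo, the only halogen shown at this position, extends the flat picture to a halogen, with no change at the digits printed from compound 3 to compound 4 (within the scatter) and a number 1 percentage points higher from compound 2 to compound 4 (within the scatter) and also no change at the digits printed from compound 1 to compound 4 (within the scatter) on this site. On this aromatic carbon, para to a large group, a single iodine atom and a heptyl chain of 7 carbons cannot be told apart in this read-out. No available evidence bears on this result.

Still open, as far as these compounds go, is whether an amine or a carboxylic acid at this position would move the read-out. Also open, from the compounds shown here alone, is whether any change elsewhere on the shared core would do so.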